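This account rests on a few compounds, and the source may have more. Where it says the series, first, only, none or still open, it means among the compounds named here.

Of the compounds shown here, three built on one shared core have been tested in a functional assay on HCC1806 cells (Homo sapiens) for inhibition, read by sulforhodamine B assay, tested at 10 uM; a higher number here means more inhibition at the concentration tested (going by the name of the read-out), a lower number less inhibition. Compound 1 `CC(=O)N1N=C(c2ccc(N3CCN(C)CC3)cc2)CC1c1ccc(N(C)C)cc1` gives -0.8%, and compound 2 `Cc1ccc(C(=O)N2N=C(c3ccc(N4CCN(C)CC4)cc3)CC2c2ccc(N(C)C)cc2)cc1` gives -2.5%; the change between them, a number 1.7 percentage points lower from compound 1 to compound 2 (within the scatter), stays within the scatter. Compound 3 `Cc1ccc(S(=O)(=O)N2N=C(c3ccc(N4CCN(C)CC4)cc3)CC2c2ccc(N(C)C)cc2)cc1` gives 32.2%, the highest of the three numbers, reached through a number 33 percentage points higher from compound 1 to compound 3 (beyond the scatter) and a number 34.7 percentage points higher from compound 2 to compound 3 (beyond the scatter). Compound 4 `CN1CCN(c2ccc(C3=NN(S(=O)(=O)c4ccc(OC(F)(F)F)cc4)C(c4ccc(N(C)C)cc4)C3)cc2)CC1` differs from compound 3 by trifluoromethoxy in place of methyl on an aromatic carbon, on the (4-methylphenyl)sulfonyl group, para to a large group. Going by the values given here, no measured step touches this position: the two large steps concern the group on the amine nitrogen in a ring, which compound 4 keeps unchanged. A small step is therefore expected, a number 2.8 percentage points higher from compound 3 to compound 4 (within the scatter), in either direction. Compound 4 is estimated at 35%, between 15% and 60%.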

Compound 4, a percentage reported as inhibition, at one concentration (the size of the read-out at that concentration, not a potency): 70.8%
Estimate against measurement, compound 4: 35.8 percentage points below, outside the stated range (above it).
By their numbers in this assay, from the lowest: compounds 2 and 1 (each within the scatter of the next); then compound 3; then compound 4.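

In this assay, the change from 4-methylphenyl to 4-(trifluoromethoxy)phenyl gives a number 38.6 percentage points higher from compound 3 to compound 4 (beyond the scatter). Going by these compounds alone, the group at the far end of the sulfonyl substituent therefore matters too: earlier steps showed only that changing the whole group on the ring nitrogen could make a large difference, whereas here the sulfonyl link stays and a large step still appears. No supporting data explain this step. As far as these compounds go, how a methoxy group or a chlorine atom on the same carbon would compare stays open, as does whether trifluoromethoxy would raise the carbonyl-linked compound 2 similarly.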